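A Sulfonyl Group Added to Compound 2

This account rests on a few compounds, and the source may have more. Where it says the series, first, only, none or still open, it means among the compounds named here.

Measured values:
- Compound 1 `Cc1ccc(S(=O)(=O)N2C/C(=C\c3cccnc3)C(=O)/C(=C/c3ccccc3F)C2)cc1`: 10300 nM
- Compound 2 `O=C1/C(=C/c2ccncc2)CNC/C1=C\c1ccccc1F`: 18400 nM

Both compounds were tested in a functional assay on SMMC-7721 cells (Homo sapiens) for cytotoxicity, read by MTT assay, with a stated time of 24 h; a lower number here means a stronger inhibitor, a higher number a weaker inhibitor. Among the measured compounds shown here, only two numbers are available, and they lie within the usual scatter of each other. Compound 2 therefore sits level with compound 1, and no ranking can be drawn between them.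

The next compound to be tested is compound 3 `Cc1ccc(S(=O)(=O)N2C/C(=C\c3ccncc3)C(=O)/C(=C/c3ccccc3F)C2)cc1`. The structural change from compound 2 is (4-methylphenyl)sulfonyl in place of hydrogen on an amine nitrogen in a ring. In words, (4-methylphenyl)sulfonyl stands in place of hydrogen on an amine nitrogen in a ring.

For the measured compounds named here, no measured pair shows the effect of this change alone, so any forecast is uncertain. The closest guide is compound 1, which also carries (4-methylphenyl)sulfonyl and gives 10300 nM in this assay. Compound 3 is therefore expected to fall near that value. The expected change is a small move toward a lower number, about the size of the usual scatter: a 1.9-fold lower number from compound 2 to compound 3 (0.29 log units; within the scatter). For compound 3 the estimated value is 9500 nM, with an expected range from 3800 nM to 22000 nM.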

Compound 3, half-maximal inhibitory concentration: 13200 nM
Estimate against measurement, compound 3: 1.4-fold (0.14 log units) below, within the range that was stated.
By their numbers in this assay, from the lowest: compounds 1, 3 and 2 (each within the scatter of the next).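

Among the compounds shown here, the pair of compound 2 and compound 3 is the first direct reading of this change: in this assay, (4-methylphenyl)sulfonyl in place of hydrogen on the amine nitrogen in the ring gives a 1.4-fold lower number from compound 2 to compound 3 (0.14 log units; within the scatter). So a group of this size can stand at this position without moving the number beyond the scatter, and the free amine hydrogen is not needed to keep cytotoxicity at this level in these cells. The pair of compound 1 and compound 3 adds a second reading with the sulfonyl group held fixed: pyridin-4-yl in place of pyridin-3-yl gives a 1.3-fold higher number from compound 1 to compound 3 (0.11 log units; within the scatter), so the two pyridine attachments cannot be told apart here, and no measurement available bears on why either change has so little effect.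

From the compounds shown here alone, whether a much smaller group on the same ring nitrogen, such as methyl or acetyl, would give a step beyond the scatter remains open. A pyridin-2-yl or a plain phenyl in place of the pyridine ring is equally open, and so far neither site has shown a step larger than the scatter.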